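The compounds below may be only part of what the source reports. "The series", "measured", "known", "first", "only" and "open" are said of these compounds alone.

Measured in a functional assay on LOX IMVI cells (Homo sapiens) for inhibition, read by sulforhodamine B assay, with a stated time of 48 h; a lower number here means a stronger inhibitor of growth, a higher number a weaker inhibitor of growth:

compound 1, `COc1cc(-c2nn(-c3cccc(NC(=O)Nc4cc(C(F)(F)F)cc(C(F)(F)F)c4)c3)cc2-c2ccncc2)ccc1Cl`: 783 nM
compound 2, `COc1cc(-c2nn(-c3cccc(NC(=O)Nc4ccc(Cl)c(Cl)c4)c3)cc2-c2ccncc2)ccc1Cl`: 954 nM
compound 3, `O=C(Nc1cccc(-n2cc(-c3ccncc3)c(-c3ccc(Cl)c(O)c3)n2)c1)Nc1ccc(Cl)c(Cl)c1`: 939 nM

The three values sit within the scatter of one another, so no order among them is claimed. The cores of compound 1 and compound 2 differ, and that difference is not broken down here. Compound 2 and compound 3 differ by one change, (hydrogen in place of methyl on an oxygen on an aromatic ring), which gave a 1.0-fold lower number from compound 2 to compound 3 (0.01 log units; within the scatter).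

Compound 4, `O=C(Nc1cccc(-n2cc(-c3ccncc3)c(-c3ccc(Cl)c(O)c3)n2)c1)Nc1cc(C(F)(F)F)cc(C(F)(F)F)c1`, is not yet measured. It carries the same change from compound 1, (hydrogen in place of methyl on an oxygen on an aromatic ring), at the same place. Because the change gave a 1.0-fold lower number from compound 2 to compound 3 (0.01 log units; within the scatter), the expected step is a 1.0-fold higher number from compound 1 to compound 4 (0.01 log units; within the scatter), a number close to that of compound 1.

For compound 4 the estimate in this assay is 800 nM, expected to lie between 400 nM and 1600 nM.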

Compound 4, concentration for 50% growth inhibition: 712 nM
Compound 4: the middle estimate sits 1.1-fold (0.05 log units) above what was measured; measured number inside the range.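

In this assay, going from methoxy to hydroxy on the 4-chloro-3-methoxyphenyl group gave a 1.1-fold lower number from compound 1 to compound 4 (0.04 log units; within the scatter). The two cores compared agree on this change: the same change on two cores in this assay, a 1.0-fold lower number (0.01 log units; within the scatter) from compound 2 to compound 3 and a 1.1-fold lower number (0.04 log units; within the scatter) from compound 1 to compound 4, 1.1-fold (0.03 log units) apart, within the scatter of two such steps. Within these two pairs, the change therefore carries from one core to the other and leaves the growth-inhibition numbers alike, but two pairs do not establish a rule for the series, and a result within the scatter does not show that methyl and hydrogen at this oxygen are equivalent in any other respect or at any other core.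

The compounds shown leave open how a longer chain on that oxygen, such as ethyl or propyl, would read. They also leave open the effect of an amine or a carboxylic acid in place of the hydroxy.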